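Moving the methyl along the acid chain of compound 3

A few compounds are considered here, and "the series" means these few. Any claim that something is new, unique, unknown or untested is made for them only; others in the source may bear on it.

Of the compounds shown here, three have been tested in a functional assay (lung) for inhibition, with Cavia porcellus as the target; on this read-out higher numbers stand for weaker inhibition and lower numbers for stronger inhibition. Compound 1 `c1ccc2nc(COc3ccc(CC4CCCC4Cc4nnn[nH]4)cc3)ccc2c1` gives 20 nM, compound 2 `c1ccc2nc(COc3ccc(OCCCc4nnn[nH]4)cc3)ccc2c1` gives 250 nM, and compound 3 `CC(CCCC(=O)O)c1cccc(OCc2ccc3ccccc3n2)c1` gives 500 nM. Of these, only compound 1 is separated from compound 3 by more than the scatter of the method; the numbers of compound 2 and compound 3 lie within it, so the two cannot be ordered against each other. Compound 3 thus sits at the far end of the series from compound 1, with compound 2 close beside it.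

Compound 4 `CC(CCCc1cccc(OCc2ccc3ccccc3n2)c1)C(=O)O` has not yet been measured in this assay. It keeps every atom of compound 3 and differs only in how they are joined: 4-carboxypentyl in place of 4-carboxy-1-methylbutyl on an aromatic carbon. The carboxylic acid remains, the chain length is unchanged, and the group still hangs from the same aromatic carbon of the shared core.

For the measured compounds named here, with no step between measured compounds to lean on, a change this small is expected to stay within the scatter, and the step of no change at the digits printed from compound 3 to compound 4 (within the scatter) is estimated to show no clear direction. Compound 4 is therefore expected to give about 500 nM, within a range from 150 nM to 1600 nM in this assay.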

Compound 4, half-maximal inhibitory concentration: 75 nM
Beside the measured number, compound 4's estimate is 6.7-fold (0.82 log units) above it; measured number outside the range, below it.
By their numbers in this assay, from the lowest: compound 1; then compound 4; then compounds 2 and 3 (each within the scatter of the next).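

In this assay, for the compounds shown here, placing 4-carboxypentyl in place of 4-carboxy-1-methylbutyl on an aromatic carbon, meta to a large group, gives a 6.7-fold lower number from compound 3 to compound 4 (0.82 log units; beyond the scatter), so the read-out at this position responds to how the same atoms of the chain are joined, which the earlier compounds, differing from one another in more than one place, could not show. The two groups have the same counts of heavy atoms, double bonds, hydrogen-bond donors and hydrogen-bond acceptors, and neither has a ring, so these counts do not separate them and the step belongs to the move of the methyl along the chain alone. Nothing among the available data accounts for the size of this step.

The compounds shown leave open whether the methyl itself is needed at its new place on the chain, or whether an unbranched hexanoic acid chain, or an ethyl group at that same chain carbon, would read the same way. They also leave open whether the step would hold with an amide in place of the carboxylic acid, or on a longer chain.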